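The source may hold more compounds than are shown below. What is called first, only, known or untested is meant among the compounds shown, and "the series" means these compounds.

In an assay for inhibition of MAP kinase-interacting serine/threonine-protein kinase 1 (Homo sapiens), read by luminescence and ADP-Glo, with a stated time of 2 h (a higher number here means a weaker inhibitor, a lower number a stronger inhibitor), compound 2 `O=c1ccc(-c2ccc3cn[nH]c3c2)cn1Cc1cccc(C(F)(F)F)c1` gives 40 nM, and compound 3 `Nc1cccc(Cn2cc(-c3ccc4cn[nH]c4c3)ccc2=O)c1` gives 287 nM. Compound 1 `Cn1ncc2ccc(-c3ccc(=O)n(Cc4ccccc4)c3)cc21` reaches only a limit of the assay, > 2000 nM. Within the data shown here, the one measured step is a 7.2-fold higher number from compound 2 to compound 3 (0.86 log units; beyond the scatter), so compound 3 stands at the higher of the two numbers in this assay. Compound 4 `O=c1ccc(-c2ccc3cn[nH]c3c2)cn1Cc1ccccc1` differs from compound 3 by hydrogen in place of amino on an aromatic carbon. Among the measured compounds shown here, only the step from compound 2 to compound 3 bears on this change, and it exchanged one group for another rather than removing one; no measured step covers the loss of the amino itself. A number between the two measured values is expected for compound 4, that is a step of a 1.9-fold lower number from compound 3 to compound 4 (0.28 log units; within the scatter). The estimate for compound 4 in this assay is 150 nM, within 50 nM to 500 nM.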

Compound 4, half-maximal inhibitory concentration: 315 nM
For compound 4 the middle estimate is 2.1-fold (0.32 log units) below the measured one, and the stated range covers the measured number.
By their numbers in this assay, from the lowest: compound 2; then compounds 3 and 4 (each within the scatter of the next). At a limit, above all of these: compound 1.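

In this assay amino and hydrogen on this aromatic carbon cannot be told apart, with a 1.1-fold higher number from compound 3 to compound 4 (0.04 log units; within the scatter) for 3-aminobenzyl to benzyl. Trifluoromethyl alone separates at this place, with a 7.9-fold higher number from compound 2 to compound 4 (0.90 log units; beyond the scatter) when hydrogen replaces it, a gap matching the one already seen with amino. On the aromatic nitrogen, an at least 6.3-fold lower number from compound 1 to compound 4 (0.80 log units; beyond the scatter) is the reading for hydrogen in place of methyl, and the value of compound 1 in that step is a limit of the assay, not a number.

Open, on these data alone, is whether chloro, methoxy or a carboxylic acid on this carbon would fall with trifluoromethyl or with amino and hydrogen. Also open, as far as these compounds go, is how ethyl on the aromatic nitrogen would read.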